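This account rests on a few compounds, and the source may have more. Where it says the series, first, only, none or still open, it means among the compounds named here.

Measured in a functional assay on V79 cells (Cricetulus griseus) for cytotoxicity, read by colony formation; a lower number here means a stronger inhibitor, a higher number a weaker inhibitor:
- compound 1 `CCNCC1CCN(c2c(F)cc3c(=O)c(C(=O)O)cn(C4CC4)c3c2C(F)(F)F)C1`: 120 ug/mL
- compound 2 `CNCC1(C)CCN(c2nc3c(cc2F)c(=O)c(C(=O)O)cn3C2CC2)C1`: 58 ug/mL
- compound 3 `Nc1c(F)c(N2CCC(N)C2)cc2c1c(=O)c(C(=O)O)cn2C1CC1`: 54 ug/mL

Compound 3 lies within the scatter of compound 2, and together they sit at the low end of this small set. Compound 1 gives a higher number than compound 3, a gap beyond the scatter. Compound 4 `CCc1c(F)c(N2CCC(N)C2)cc2c1c(=O)c(C(=O)O)cn2C1CC1` has ethyl in place of amino on an aromatic carbon, ortho to a fluoro group (ethyl in place of amino on an aromatic carbon). Within the data shown here, no measured pair shows this change, so the data offer no direct guide to its size in this assay, and no shift beyond the scatter is expected. The expected step, a 1.1-fold higher number from compound 3 to compound 4 (0.05 log units; within the scatter), is estimated to stay within the scatter. For compound 4 the estimated value is 60 ug/mL, with an expected range from 25 ug/mL to 140 ug/mL.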

Compound 4, half-maximal inhibitory concentration: 46 ug/mL
Estimate against measurement, compound 4: 1.3-fold (0.12 log units) above; measured number inside the range.
By their numbers in this assay, from the lowest: compounds 4, 3 and 2 (each within the scatter of the next); then compound 1.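

Ethyl in place of amino on an aromatic carbon, ortho to a fluoro group, gives a 1.2-fold lower number from compound 3 to compound 4 (0.07 log units; within the scatter) in this assay and is the first comparison in this set that differs in one place. Here, losing the amino group's hydrogen-bond donor and acceptor goes with no shift beyond the scatter. Nothing available explains this result.

Going by these compounds, whether methyl, hydroxyl or a longer chain such as propyl on this carbon would also stay within the scatter remains open. So does whether this exchange behaves alike with an amine other than the 3-aminopyrrolidin-1-yl group.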